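This account rests on a few compounds, and the source may have more. Where it says the series, first, only, none or still open, it means among the compounds named here.

Within the data shown here, compound 1 `COc1ccc(-n2cc(-c3ccccc3)c(-c3ccc4c(c3)NC(=O)CO4)n2)cc1` gives 42.6% in a functional assay on A549 cells (Homo sapiens) for cytotoxicity, read by colorimetric assay and MTT assay, with a stated time of 3 days, tested at 20 uM (on this read-out higher numbers stand for a weaker effect at the one concentration tested and lower numbers for a stronger effect), the lowest of the three numbers so far. Compound 2 `O=C1COc2ccc(-c3nn(-c4ccc(Br)cc4)cc3-c3ccccc3)cc2N1` gives 58.8% and compound 3 `O=C1COc2ccc(-c3nn(-c4ccc(Cl)cc4)cc3-c3ccccc3)cc2N1` gives 52.4% in this assay. Compound 4 `O=C1COc2ccc(-c3nn(-c4ccccc4)cc3-c3ccccc3)cc2N1` differs from compound 1 by hydrogen in place of methoxy on an aromatic carbon. The measured steps that touch this position are a number 16.2 percentage points higher from compound 1 to compound 2 (beyond the scatter) and a number 9.8 percentage points higher from compound 1 to compound 3 (within the scatter), one beyond and one within the scatter; the two halogen analogues sit a number 6.4 percentage points lower from compound 2 to compound 3 (within the scatter). Among the measured compounds shown here, no measured step removes the group entirely, so the direction rests on the halogen swaps alone. The expected step is a number 7.4 percentage points higher from compound 1 to compound 4 (within the scatter), upward if anything, with a result within the scatter also plausible. Compound 4 is estimated at 50% in this assay, within the range 36% to 64%.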

Compound 4, a percentage reported as activity, at one concentration (the size of the read-out at that concentration, not a potency): 59.7%
Estimate against measurement, compound 4: 9.7 percentage points below; the range from low to high includes it.
By their numbers in this assay, from the lowest: compounds 1, 3, 2 and 4 (each within the scatter of the next, the first and the last beyond it).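

In this assay the direct removal of methoxy reads a number 17.1 percentage points higher from compound 1 to compound 4 (beyond the scatter), so 4-methoxyphenyl goes with a stronger effect than phenyl. Hydrogen cannot be told apart from either halogen at this place: a number 7.3 percentage points higher from compound 3 to compound 4 (within the scatter) and a number 0.9 percentage points higher from compound 2 to compound 4 (within the scatter). No measurement at hand explains the methoxy step. Open, on these data alone, is whether ethoxy, a longer chain, or an amine at this place would match methoxy or fall with hydrogen and the halogens. With a single concentration on one cell line, the compounds shown also leave open how far this step would hold as a potency.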